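Pyrazole for Thiophene at the Biaryl Terminus of a Urea

The compounds below may be only part of what the source reports. "The series", "measured", "known", "first", "only" and "open" are said of these compounds alone.

Two ureas sharing one core have been measured in an assay on microsomes from intestine for inhibition of acyl-CoA:cholesterol acyltransferase (Oryctolagus cuniculus); a higher number here means a weaker inhibitor, a lower number a stronger inhibitor. Compound 1 `Cc1cc(C)c(NC(=O)N(Cc2ccc(-c3cccs3)cc2)C2CCCCCC2)c(C)c1` gives 22 nM. Compound 2 `Cc1cc(C)c(NC(=O)N(Cc2ccc(-c3ccsc3)cc2)C2CCCCCC2)c(C)c1` gives 19 nM. Among the measured compounds shown here, the step of a 1.2-fold lower number from compound 1 to compound 2 (0.06 log units; within the scatter) is the only measured comparison, and it lies within the scatter, so compound 2 stands at the lower of two numbers that cannot be told apart.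

Compound 3 `Cc1cc(C)c(NC(=O)N(Cc2ccc(-c3cc[nH]n3)cc2)C2CCCCCC2)c(C)c1` differs from compound 2 in one place: 1H-pyrazol-3-yl in place of thiophen-3-yl on an aromatic carbon. The measured step bears on this only loosely. It showed that moving the point of attachment of the thiophene, from thiophen-2-yl to thiophen-3-yl, changed nothing beyond the scatter; it says nothing about exchanging the ring for a pyrazole that brings a hydrogen-bond donor and a second hetero atom. For the measured compounds named here, with no direct precedent, a small to moderate weakening of compound 3 in this assay is expected, but a step within the scatter would not be surprising either. For compound 3 a value of 45 nM is estimated, with a range from 12 nM to 180 nM. This estimate means an expected step of a 2.4-fold higher number from compound 2 to compound 3 (0.37 log units; beyond the scatter).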

Compound 3, half-maximal inhibitory concentration: 52 nM
Compound 3: the middle estimate sits 1.2-fold (0.06 log units) below what was measured, and the stated range covers the measured number.
By their numbers in this assay, from the lowest: compounds 2 and 1 (each within the scatter of the next); then compound 3.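

Among the compounds shown here, exchanging the thiophene for a pyrazole is the first change at this position to move the number in this assay beyond the scatter, with a 2.7-fold higher number from compound 2 to compound 3 (0.44 log units; beyond the scatter) and a 2.4-fold higher number from compound 1 to compound 3 (0.37 log units; beyond the scatter), whereas compound 1 and compound 2 could not be told apart. The position therefore responds to the identity of the terminal ring and not only, as far as the thiophenes showed, to a five-membered aromatic ring being present on the aromatic carbon para to a large group, although both steps are modest and the ring with 2 hetero atoms and 1 hydrogen-bond donor costs only a limited amount. No outside information accompanies these numbers to explain the step.

Still open, on these data alone, is whether the step follows the hydrogen on the pyrazole nitrogen or the second ring nitrogen, a question that a pyrazole with a methyl group on that nitrogen, or an oxazole or imidazole in the same place, would bear on. Also open, as far as these compounds go, is how a six-membered ring such as pyridine or plain phenyl would compare with these five-membered rings.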